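Methoxy Enters the Anilino Ring of Compound 1

The source may hold more compounds than are shown below. What is called first, only, known or untested is meant among the compounds shown, and "the series" means these compounds.

Compound 1 `Cc1nc(SCC(=O)Nc2nc(-c3ccc(Cl)cc3)cs2)n(Nc2ccccc2)c1C` was examined in a functional assay on CAKI-1 cells (Homo sapiens) for antiproliferative activity, read by sulforhodamine B assay, with a stated time of 48 h (a higher number here means a weaker inhibitor of growth, a lower number a stronger inhibitor of growth), where compound 1 gives 22600 nM. Among the two compounds measured so far, compound 1 has the highest number; the nearest is compound 2 `Cc1ccc(Nn2c(SCC(=O)Nc3nc(-c4ccccc4)cs3)nc(C)c2C)cc1`, which in this assay gives 6100 nM, a gap beyond the usual scatter. Among the measured compounds shown here, compound 2 differs from compound 1 in more than one place, so no single-change step connects them, and its value shows only where it stands. Compound 3 `COc1ccc(Nn2c(SCC(=O)Nc3nc(-c4ccc(Cl)cc4)cs3)nc(C)c2C)cc1` has not yet been measured. It differs from compound 1 by methoxy in place of hydrogen on an aromatic carbon. For the measured compounds named here, no measured pair isolates this change on the shared core, so any expectation rests on the two values shown. A modest move toward a lower number is expected, a 2.1-fold lower number from compound 1 to compound 3 (0.31 log units; beyond the scatter). For compound 3 the estimate is 11000 nM, with a range from 4000 nM to 30000 nM.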

Compound 3, concentration for total growth inhibition: > 100000 nM
Compound 3 ended at the assay's limit; the forecaster's own chance of this, stated with the estimate: 10%; at least 9.0-fold (0.95 log units) between middle value and limit.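

Among the compounds shown here, on the anilino ring, para to a large group, methoxy in place of hydrogen gives the first single-change step, and it points toward weaker growth inhibition: an at least 4.4-fold higher number from compound 1 to compound 3 (0.64 log units; beyond the scatter). In this assay compound 3 gives > 100000 nM, which is a limit of the assay and not a number. The step therefore fixes only the direction and a lower bound on the size of the change, and its upper end cannot be read: the limit of > 100000 nM in this assay, at which 1 of the 3 values shown sits.

This single pair cannot separate an effect of methoxy itself from one that any substituent at this position might have, and a hydroxyl, an amine or a fluorine in the same place could show which holds. From the compounds shown here alone, whether phenyl to 4-methoxyphenyl acts in the same direction on a different core also remains open.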